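Isobutyl to Sec-Butyl on the Chain Carbon

This account rests on a few compounds, and the source may have more. Where it says the series, first, only, none or still open, it means among the compounds named here.

Of the compounds shown here, three have been measured in a functional assay for inhibition, read by spectrophotometry, with a stated time of 20 min, tested at 2 mg/mL; a lower number here means a weaker effect, a higher number a stronger effect of the compound at the concentration tested. Compound 1 `CCC(C)C(C(=O)Nc1ccc(C(C)=O)cc1)N(C(=O)c1ccccc1)S(=O)(=O)c1ccc(C)cc1` gives 25.7%. Compound 2 `CC(=O)c1ccc(NC(=O)CN(C(=O)c2ccccc2)S(=O)(=O)c2ccc([N+](=O)[O-])cc2)cc1` gives 20.6%, and compound 3 `CC(=O)c1ccc(NC(=O)C(CC(C)C)N(C(=O)c2ccccc2)S(=O)(=O)c2ccc([N+](=O)[O-])cc2)cc1` gives 54.2%. Compound 3 stands highest of the three: compound 1 is nearest to it and compound 2 furthest, both separated from it by more than the scatter. For the measured compounds named here, the only single-site step among the measured compounds, a number 33.6 percentage points higher from compound 2 to compound 3 (beyond the scatter), puts isobutyl in place of hydrogen on a saturated chain carbon bound to an amide-type nitrogen and a carbonyl carbon.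

Compound 4 `CCC(C)C(C(=O)Nc1ccc(C(C)=O)cc1)N(C(=O)c1ccccc1)S(=O)(=O)c1ccc([N+](=O)[O-])cc1` has not been measured. It differs from compound 3 by sec-butyl in place of isobutyl on a saturated chain carbon bound to an amide-type nitrogen and a carbonyl carbon. Going by the values given here, no measured step bears directly on this exchange of one branched group for another. The step from compound 2 to compound 3 shows that a group at this carbon matters greatly compared with hydrogen, but says nothing about which branched group is better. Compound 1 also carries sec-butyl at this carbon, yet differs from compound 3 in a second place as well, so the value of compound 1, 25.7%, is only a loose hint toward a lower number. Compound 4 is therefore expected to give a somewhat lower number, a step estimated as a number 14.2 percentage points lower from compound 3 to compound 4 (beyond the scatter). The estimate for compound 4 is 40%, between 20% and 60%.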

Compound 4, a percentage reported as inhibition, at one concentration (the size of the read-out at that concentration, not a potency): 31.7%
For compound 4 the middle estimate is 8.3 percentage points above the measured one; measured number inside the range.
By their numbers in this assay, from the lowest: compounds 2, 1 and 4 (each within the scatter of the next, the first and the last beyond it); then compound 3.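

In this assay, for the compounds shown here, this exchange gives the first direct reading of how the two branched groups compare on the chain carbon, and the arrangement of the same carbon atoms matters here (a number 22.5 percentage points lower from compound 3 to compound 4 (beyond the scatter)). Sec-butyl in place of hydrogen still raises the number (a number 11.1 percentage points higher from compound 2 to compound 4 (beyond the scatter)), but this gain is smaller than the one seen with isobutyl (a number 33.6 percentage points higher from compound 2 to compound 3 (beyond the scatter)), so the earlier step reflected the particular group and not simply the presence of a four-carbon substituent. With sec-butyl held on the chain carbon, nitro in place of methyl on an aromatic carbon leaves the two compounds inseparable (a number 6 percentage points higher from compound 1 to compound 4 (within the scatter)), which means the low number of compound 1 gave no separate sign of an effect from that aromatic exchange.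

Still open, on these data alone, is how a straight butyl chain, a cyclohexyl group or an amine-bearing chain would read on this carbon, and whether methyl and nitro would also stay inseparable with isobutyl there. The compounds come with no measurement that explains why the two branched groups differ.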